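One Ring Group for Another: From Compound 3 to Compound 4

A few compounds are considered here, and "the series" means these few. Any claim that something is new, unique, unknown or untested is made for them only; others in the source may bear on it.

Of the compounds shown here, three built on a shared core have been measured in a functional assay on the whole organism with Rattus norvegicus as the target; on this read-out lower numbers stand for an effect already at smaller amounts and higher numbers for an effect only at larger amounts of compound. Compound 1 `Nc1ncnc2nc(-c3ccc(N4CCC(COC5CCOCC5)CC4)nn3)cc(-c3cccc(Br)c3)c12` gives 5 umol/kg. Compound 2 `Nc1ncnc2nc(-c3ccc(N4CCC(=NOC5CCOCC5)CC4)nn3)cc(-c3cccc(Br)c3)c12` gives 2 umol/kg in this assay. Compound 3 `N#C[C@H]1CN(c2ccc(-c3cc(-c4cccc(Br)c4)c4c(N)ncnc4n3)cn2)C[C@H]1O` gives 4 umol/kg in this assay. Among these three numbers compound 3 holds the second highest; its nearest neighbour is compound 1 and its furthest is compound 2, yet both gaps stay within the usual scatter of repeated measurements, so the three compounds cannot be told apart on this read-out.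

Compound 4 `Nc1ncnc2nc(-c3ccc(N4CCC5(CC4)COCO5)nc3)cc(-c3cccc(Br)c3)c12` has not yet been measured in this assay. It keeps the shared core and differs from compound 3 in one place: a group of 10 heavy atoms (7 carbon, 1 nitrogen, 2 oxygen; one five-membered non-aromatic ring with 2 hetero atoms, one six-membered non-aromatic ring with 1 hetero atom) in place of a group of 8 heavy atoms (5 carbon, 2 nitrogen, 1 oxygen; one five-membered non-aromatic ring with 1 hetero atom), on an aromatic carbon. For the measured compounds named here, no measured pair isolates such a swap, so there is no measured step to set its size. Since compounds 1, 2 and 3 carry quite different outer groups and still land within the scatter of one another, the change is expected to amount to no change at the digits printed from compound 3 to compound 4 (within the scatter), with no direction beyond the scatter. Compound 4 is therefore estimated at 4 umol/kg in this assay, with a likely range from 1.5 umol/kg to 12 umol/kg.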

Compound 4, dose for half-maximal effect: 2 umol/kg
For compound 4 the middle estimate is 2.0-fold (0.30 log units) above the measured one; the measured number falls inside the stated range.
By their numbers in this assay, from the lowest: compounds 2, 4, 3 and 1 (each within the scatter of the next, the first and the last beyond it).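

On this aromatic carbon, next to the ring nitrogen and para to a large group, the 3-cyano-4-hydroxypyrrolidin-1-yl group of compound 3 and the two-ring group of compound 4 cannot be told apart in this assay: the swap gives a 2.0-fold lower number from compound 3 to compound 4 (0.30 log units; within the scatter) and leaves the two compounds on the same footing. This is the first pair shown that differs in one place, and it indicates that this read-out does not depend here on the nitrile triple bond, the hydrogen-bond donor or the 2 defined stereocentres, all of which go with the departing group, while a second non-aromatic ring comes in. No information is available on why the two groups read alike.

From the compounds shown here alone, the swap changes all of these features at once, so the contribution of each one alone stays open, as it would for a plain pyrrolidin-1-yl group carrying neither nitrile nor hydroxyl. Going by these compounds, it also remains open how a quite different group on this carbon, such as a carboxylic acid or a short open-chain amine, would read.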